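This account rests on a few compounds, and the source may have more. Where it says the series, first, only, none or still open, it means among the compounds named here.

Three compounds have been measured in an ADME assay for permeability, using PAMPA, with a stated time of 6 h, tested at 100 uM; on this read-out higher numbers stand for higher permeability and lower numbers for lower permeability:

compound 1 `NC(=O)c1cc[n+](CCCC[n+]2ccc(/C=N/O)c(Cl)c2)cc1` gives 1 10^-6 cm/s
compound 2 `NC(=O)c1cc[n+](C/C=C/C[n+]2cc(Cl)c(/C=N/O)c(Cl)c2)cc1` gives 2.21 10^-6 cm/s
compound 3 `NC(=O)c1cc[n+](CCCC[n+]2cc(Cl)c(/C=N/O)c(Cl)c2)cc1` gives 1.4 10^-6 cm/s

Compound 4 `NC(=O)c1cc[n+](C/C=C/C[n+]2ccc(/C=N/O)c(Cl)c2)cc1` has not yet been measured in this assay.

The change that turns compound 3 into compound 1 is hydrogen in place of chloro on an aromatic carbon. Its effect was a 1.4-fold lower number from compound 3 to compound 1 (0.15 log units; within the scatter). The same change, at the same kind of place, turns compound 2 into compound 4: hydrogen in place of chloro on an aromatic carbon. How the core of compound 2 differs from the core of compound 3 is not broken down here; the two values lie within the usual scatter of each other.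

Since the step from compound 3 to compound 1 stayed within the scatter, the expectation is that removing the chloro from compound 2 moves the number only a little as well, and the expected step is a 1.4-fold lower number from compound 2 to compound 4 (0.14 log units; within the scatter), resting on a 1.4-fold lower number from compound 3 to compound 1 (0.15 log units; within the scatter). Compound 4 is therefore estimated at 1.6 10^-6 cm/s, likely between 0.8 10^-6 cm/s and 3.2 10^-6 cm/s.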

Compound 4, apparent permeability in the ADME assay: 2.6 10^-6 cm/s
Compound 4: the middle estimate sits 1.6-fold (0.21 log units) below what was measured, and the stated range covers the measured number.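

In the ADME assay compound 2 gives 2.21 10^-6 cm/s and compound 4 gives 2.6 10^-6 cm/s. In the ADME assay, putting hydrogen in place of chloro on an aromatic carbon gives a 1.2-fold higher number from compound 2 to compound 4 (0.07 log units; within the scatter), and beside the earlier step the change carries from one core to the other with no difference that can be told apart from the scatter: the same change on two cores in the ADME assay, a 1.4-fold lower number (0.15 log units; within the scatter) from compound 3 to compound 1 and a 1.2-fold higher number (0.07 log units; within the scatter) from compound 2 to compound 4, 1.6-fold (0.22 log units) apart, within the scatter of two such steps. Among these compounds, this rests on only two pairs of compounds, so it does not show that the step would stay this small on any other core, and steps this small cannot separate a slight real effect from none. In a physicochemical assay for acid dissociation, read by spectrophotometry, at pH 4.6, compound 2 gives 7.55 and compound 4 gives 7.6. In the physicochemical assay the same change gives a number 0.05 log units higher from compound 2 to compound 4 (within the scatter), again a small step, but on one core only, so nothing can be said there about carrying it across.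

The compounds shown leave open what happens when a different group, such as an amine, a carboxylic acid or a methoxy group, takes the place of the chloro. Also open, on these data alone, is how these numbers would respond to a longer chain in these compounds.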